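A few compounds are considered here, and "the series" means these few. Any claim that something is new, unique, unknown or untested is made for them only; others in the source may bear on it.

Series notes, step from compound 3 to compound 4.

The shared core is that of compound 1 `COc1cc(C(=O)N/N=C/c2c(Cl)cccc2Cl)cc(OC)c1OC`, compound 2 `COc1cc(C(=O)N/N=C/c2ccc(F)cc2)cc(OC)c1OC` and compound 3 `COc1cc(C(=O)N/N=C/c2ccccc2F)cc(OC)c1OC`. In a functional assay on PC-3 cells (Homo sapiens) for antiproliferative activity, read by MTT assay, tested at 5 uM (a higher number here means a stronger effect of the compound at the concentration tested, a lower number a weaker effect), compound 1 gives 52.1%, compound 2 gives 82.8% and compound 3 gives 81.8%. Compound 3 stands second highest of the three numbers; its nearest neighbour is compound 2, since a number 1 percentage points lower from compound 2 to compound 3 (within the scatter), and its furthest is compound 1, since a number 29.7 percentage points higher from compound 1 to compound 3 (beyond the scatter).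

Compound 4 `COc1cc(C(=O)N/N=C/c2ccc(Cl)c(Cl)c2)cc(OC)c1OC` differs from compound 3 in one place: 3,4-dichlorophenyl in place of 2-fluorophenyl on a carbon with a double bond to nitrogen.

Among the compounds with values here, no measured step exchanges a fluorophenyl for a 3,4-dichlorophenyl. Within the data shown here, the steps that bear on it indirectly both go from a dichlorophenyl to a fluorophenyl: a number 30.7 percentage points higher from compound 1 to compound 2 (beyond the scatter) and a number 29.7 percentage points higher from compound 1 to compound 3 (beyond the scatter). Read in reverse, they suggest that putting two chlorines back in place of one fluorine may cost something in this assay, but the chlorine pattern of compound 4 is not that of compound 1, so the size is uncertain. For compound 4 a modest drop is therefore expected, a number 13.8 percentage points lower from compound 3 to compound 4 (beyond the scatter). The estimated value for compound 4 in this assay is 68%, with a range from 48% to 88%.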

Compound 4, a percentage reported as inhibition, at one concentration (the size of the read-out at that concentration, not a potency): 31.6%
Estimate against measurement, compound 4: 36.4 percentage points above, outside the stated range (below it).
By their numbers in this assay, from the lowest: compound 4; then compound 1; then compounds 3 and 2 (each within the scatter of the next).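

In this assay, placing 3,4-dichlorophenyl on the carbon with a double bond to nitrogen gives a number 50.2 percentage points lower from compound 3 to compound 4 (beyond the scatter) and a number 51.2 percentage points lower from compound 2 to compound 4 (beyond the scatter), so both fluorophenyl compounds lie far from it. The two dichlorophenyl compounds also separate, with a number 20.5 percentage points lower from compound 1 to compound 4 (beyond the scatter), which shows that, between these two compounds, the arrangement of the chlorines matters and not only their number. Nothing available accounts for these steps.

Open, on these data alone, is whether a phenyl group carrying a single chlorine would read like the fluorophenyl compounds or like the dichlorophenyl compounds. Also open, as far as these compounds go, is how a methoxy or dimethylamino group on the phenyl ring, or a pyridine ring in its place, would read at this position.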